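Swapping a pentyloxy chain for a chlorophenyl-amino group

A few compounds are considered here, and "the series" means these few. Any claim that something is new, unique, unknown or untested is made for them only; others in the source may bear on it.

Of the compounds shown here, three sharing one core have been tested in a functional assay on SAOS-2 cells (Homo sapiens) for antiproliferative activity, read by MTT assay, with a stated time of 72 h; a lower number here means a stronger inhibitor, a higher number a weaker inhibitor. Compound 1, with structure `CCCCCOC1=C(C(=O)c2ccccc2)C(c2ccc(Br)cc2)N(CCCn2ccnc2)C1=O`, gives 9990 nM, the lowest of the three numbers. Compound 2, with structure `NC1=C(C(=O)c2ccccc2)C(c2ccc(Br)cc2)N(CCCn2ccnc2)C1=O`, gives 107000 nM, and compound 3, with structure `O=C(C1=C(Nc2ccc(Br)cc2)C(=O)N(CCCn2ccnc2)C1c1ccc(Br)cc1)c1ccccc1`, gives 23800 nM. Both changes away from compound 1 weakened inhibition: an 11-fold higher number from compound 1 to compound 2 (1.03 log units; beyond the scatter) and a 2.4-fold higher number from compound 1 to compound 3 (0.38 log units; beyond the scatter).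

The next compound, compound 4, has structure `O=C(C1=C(Nc2ccc(Cl)cc2)C(=O)N(CCCn2ccnc2)C1c1ccc(Br)cc1)c1ccccc1`. Its difference from compound 1 is (4-chlorophenyl)amino in place of pentyloxy on a double-bonded ring carbon. This closely resembles the step to compound 3, which also places an arylamino group at the same ring carbon; the two differ only in the halogen on that ring. The step of a 2.4-fold higher number from compound 1 to compound 3 (0.38 log units; beyond the scatter) is therefore the most relevant guide, with an 11-fold higher number from compound 1 to compound 2 (1.03 log units; beyond the scatter) showing that replacing pentyloxy with a nitrogen-bearing group at this position has so far always raised the number.

For compound 4 the expected step is a 2.0-fold higher number from compound 1 to compound 4 (0.30 log units; within the scatter), a modest weakening. Compound 4 is estimated at 20000 nM in this assay, with a likely range of 8000 nM to 50000 nM.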

Compound 4, half-maximal inhibitory concentration: 24800 nM
Compound 4: the middle estimate sits 1.2-fold (0.09 log units) below what was measured; measured number inside the range.
By their numbers in this assay, from the lowest: compound 1; then compounds 3 and 4 (each within the scatter of the next); then compound 2.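

Chloro in place of bromo on the aromatic ring of the arylamino group leaves the number in this assay within the scatter (a 1.0-fold higher number from compound 3 to compound 4 (0.02 log units; within the scatter)), so these two halogens cannot be told apart here. The cost of replacing pentyloxy with an arylamino group now appears with both halogens (a 2.5-fold higher number from compound 1 to compound 4 (0.39 log units; beyond the scatter)), and the 4-chlorophenyl group on the amine nitrogen, like the 4-bromophenyl group, gives a lower number than the hydrogen of compound 2 (a 4.3-fold lower number from compound 2 to compound 4 (0.63 log units; beyond the scatter)), while no measurement available here accounts for these steps.

Open, from the compounds shown here alone, is whether a methyl or methoxy group in place of the halogen would shift the number. Also open, going by these compounds, is whether a pentylamino chain would behave like pentyloxy, which would separate the effect of the linking nitrogen from that of the aromatic ring.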